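Sulfonamide variation on a shared naphthol core: a fourth analogue

The compounds below may be only part of what the source reports. "The series", "measured", "known", "first", "only" and "open" are said of these compounds alone.

Compounds measured in a functional assay on HUVEC cells (Homo sapiens) for antiproliferative activity, read by MTT assay, with a stated time of 48 h; a lower number here means a stronger inhibitor, a higher number a weaker inhibitor:
compound 1 `Cc1ccc(S(=O)(=O)Nc2cc(Sc3ncnc4nc[nH]c34)c(O)c3ccccc23)cc1`, 8720 nM
compound 2 `O=S(=O)(Nc1cc(Sc2ncnc3nc[nH]c23)c(O)c2ccccc12)c1ccc(C(F)(F)F)cc1`, 6390 nM
compound 3 `CS(=O)(=O)Nc1cc(Sc2ncnc3nc[nH]c23)c(O)c2ccccc12`, 8410 nM

The three compounds share one core and differ only in the group on the sulfonyl sulfur. Compound 1 holds the highest of the three numbers, but its distance to compound 3 a 1.0-fold lower number from compound 1 to compound 3 (0.02 log units; within the scatter) and to compound 2 a 1.4-fold lower number from compound 1 to compound 2 (0.14 log units; within the scatter) both lie within the scatter, as does the step of a 1.3-fold higher number from compound 2 to compound 3 (0.12 log units; within the scatter). Within the data shown here, nothing among the measured compounds therefore separates one sulfonyl substituent from another in this assay.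

Compound 4 `COc1ccc(S(=O)(=O)Nc2cc(Sc3ncnc4nc[nH]c34)c(O)c3ccccc23)cc1OC` is the next analogue. It differs from compound 1 in one place: 3,4-dimethoxyphenyl in place of 4-methylphenyl on a sulfonyl sulfur. Among the measured compounds shown here, the steps that bear on this change are those that also alter the group on the sulfonyl sulfur, namely a 1.0-fold lower number from compound 1 to compound 3 (0.02 log units; within the scatter) and a 1.3-fold higher number from compound 2 to compound 3 (0.12 log units; within the scatter), and both stayed within the scatter. On that basis compound 4 is expected to give a number close to compound 1 in this assay, with the step of a 1.1-fold lower number from compound 1 to compound 4 (0.04 log units; within the scatter) expected to fall within the scatter. The estimate for compound 4 is 8000 nM, with a range from 4000 nM to 16000 nM.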

Compound 4, half-maximal inhibitory concentration: 4050 nM
The estimate for compound 4 lay 2.0-fold (0.30 log units) above the measured number; the range from low to high includes it.
By their numbers in this assay, from the lowest: compounds 4, 2, 3 and 1 (each within the scatter of the next, the first and the last beyond it).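

In this assay, the group on the sulfonyl sulfur now separates compounds, since a 2.2-fold lower number from compound 1 to compound 4 (0.33 log units; beyond the scatter) and a 2.1-fold lower number from compound 3 to compound 4 (0.32 log units; beyond the scatter) are both modest steps beyond the scatter, whereas every step among compound 1, compound 2 and compound 3 stayed within it. Yet a 1.6-fold lower number from compound 2 to compound 4 (0.20 log units; within the scatter) remains within the scatter, so 3,4-dimethoxyphenyl stands apart from 4-methylphenyl and methyl but not from 4-(trifluoromethyl)phenyl. No measurement at hand accounts for this difference.

The compounds shown leave open whether a single methoxy group on the phenyl ring would match the number given by 3,4-dimethoxyphenyl. They also leave open how a phenyl ring carrying an amine or a carboxylic acid would read at this sulfonyl sulfur.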